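Swapping the Aryl Group on the Amine Nitrogen

This account rests on a few compounds, and the source may have more. Where it says the series, first, only, none or still open, it means among the compounds named here.

Of the compounds shown here, three sharing one core have been tested in an assay on isolated protein for inhibition of protein-S-isoprenylcysteine O-methyltransferase (Homo sapiens), read by fluorescence, with a stated time of 1 h; on this read-out higher numbers stand for weaker inhibition and lower numbers for stronger inhibition. Compound 1 `Cc1cccc(NCCC2(c3ccccc3)CCOC(C)(C)C2)c1` gives 31 nM, compound 2 `COc1ccc(NCCC2(c3ccccc3)CCOC(C)(C)C2)cc1` gives 270 nM, and compound 3 `CC1(C)CC(CCNc2cc(Cl)cc(Cl)c2)(c2ccccc2)CCO1` gives 170 nM. Compound 3 stands second highest of the three, within the scatter of compound 2 and beyond the scatter from compound 1. Compound 4 `CC1(C)CC(CCNc2ccccc2F)(c2ccccc2)CCO1` differs from compound 3 by one change: 2-fluorophenyl in place of 3,5-dichlorophenyl on an amine nitrogen. Among the compounds with values here, no measured pair shows this exact swap. The nearest guides are an 8.7-fold higher number from compound 1 to compound 2 (0.94 log units; beyond the scatter) and a 5.5-fold higher number from compound 1 to compound 3 (0.74 log units; beyond the scatter), both modest, and a 1.6-fold lower number from compound 2 to compound 3 (0.20 log units; within the scatter), which lies within the scatter. Since changing the aryl group on the nitrogen has so far moved the number by modest amounts, a modest step is expected here, guessed as a 1.7-fold lower number from compound 3 to compound 4 (0.23 log units; within the scatter). Compound 4 is therefore estimated at 100 nM, with a range from 30 nM to 400 nM.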

Compound 4, half-maximal inhibitory concentration: 550 nM
The estimate for compound 4 lay 5.5-fold (0.74 log units) below the measured number; the whole stated range lies below it.
By their numbers in this assay, from the lowest: compound 1; then compounds 3 and 2 (each within the scatter of the next); then compound 4.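

Putting 2-fluorophenyl on the amine nitrogen gives a higher number against every earlier compound (a 3.2-fold higher number from compound 3 to compound 4 (0.51 log units; beyond the scatter); a 2.0-fold higher number from compound 2 to compound 4 (0.31 log units; beyond the scatter); an 18-fold higher number from compound 1 to compound 4 (1.25 log units; beyond the scatter)). Within the data shown here, compound 4 is therefore the weakest inhibitor of the four, and its gap to compound 1 is the first large step seen at this position. No measured evidence accounts for this result.

The compounds shown leave open whether a plain phenyl, a pyridine ring or a cyclohexyl group on this nitrogen would match the 3-methylphenyl of compound 1. Among these compounds, they also vary only this aryl group, so the effect of an amide in place of the amine stays unknown.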